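Replacing the aroyl group of compound 2 with furan-3-yl

A few compounds are considered here, and "the series" means these few. Any claim that something is new, unique, unknown or untested is made for them only; others in the source may bear on it.

Of the compounds shown here, two have been measured so far. Compound 1 `CCOc1ccccc1C(=O)Nc1nc(-c2ccccc2)nc2c1nnn2Cc1ccccc1` gives 1850 nM in an assay (strain Wistar) for displacement of a labelled ligand from adenosine receptor A1 (Rattus norvegicus), read by scintillation counting; on this read-out lower numbers stand for stronger inhibition and higher numbers for weaker inhibition. Among the compounds with values here, compound 2 `O=C(Nc1nc(-c2ccccc2)nc2c1nnn2Cc1ccccc1)c1ccccc1C(F)(F)F` gives 550 nM in this assay, and on the numbers available it stands at the lower of the two values, with the step of a 3.4-fold lower number from compound 1 to compound 2 (0.53 log units; beyond the scatter) being the only measured step and amounting to a modest change from trifluoromethyl in place of ethoxy on an aromatic carbon.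

Compound 3 `O=C(Nc1nc(-c2ccccc2)nc2c1nnn2Cc1ccccc1)c1ccoc1` differs from compound 2 by furan-3-yl in place of 2-(trifluoromethyl)phenyl on a carbonyl carbon. Within the data shown here, no measured step bears directly on this change: the one step recorded concerns only a substituent on the aromatic ring that is now removed entirely, and nothing in the data shows how exchanging the whole ring for furan-3-yl behaves. The estimate for compound 3 therefore leans on the value of compound 2 with a wide range, and the expected step of a 1.1-fold higher number from compound 2 to compound 3 (0.04 log units; within the scatter) is set to none beyond the scatter in this assay. Compound 3 is accordingly expected to give 600 nM, estimated between 100 nM and 3500 nM.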

Compound 3, inhibition constant: 10 nM
Compound 3: middle estimate off by 60-fold (1.78 log units), on the high side; measured number below the stated range.
By their numbers in this assay, from the lowest: compound 3; then compound 2; then compound 1.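

In this assay, the ring on the carbonyl carbon proves far more consequential than the substituent on that ring: the exchange for furan-3-yl gives a 55-fold lower number from compound 2 to compound 3 (1.74 log units; beyond the scatter) and a 190-fold lower number from compound 1 to compound 3 (2.27 log units; beyond the scatter), whereas the substituent change alone gave only a 3.4-fold lower number from compound 1 to compound 2 (0.53 log units; beyond the scatter). Within the data shown here, the earlier pair showed only that the number moves modestly when one substituent on the six-membered aromatic ring of carbon only is swapped for another, while this result shows that replacing that ring with a five-membered aromatic ring with 1 hetero atom can move it much further, from either of the two substituted phenyl groups. No evidence on hand accounts for the size of this shift.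

The compounds shown change the ring type, the hetero atom and the substituent all at once, so they leave open which of these matters; unsubstituted phenyl, thiophen-3-yl and furan-2-yl on the same carbonyl carbon would begin to separate them. On these data alone, it also remains open whether the gain from furan-3-yl would persist with a change elsewhere on the shared core, such as a simple alkyl chain in place of the benzyl group.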